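Swapping the Phenyl Group on a Carbonyl Carbon

This account rests on a few compounds, and the source may have more. Where it says the series, first, only, none or still open, it means among the compounds named here.

Among the compounds with values here, only two compounds have been measured so far. In a functional assay on MCF7 cells (Homo sapiens) for cytotoxicity, read by MTT assay, with a stated time of 48 h (on this read-out higher numbers stand for weaker inhibition and lower numbers for stronger inhibition), compound 1 (`O=C(CSCc1nc2cc([N+](=O)[O-])ccc2[nH]1)c1ccccc1`) gives 18600 nM, and compound 2 (`N#Cc1sc(Nc2ccccc2)nc1NC(=O)CSCc1nc2cc([N+](=O)[O-])ccc2[nH]1`) gives 11300 nM. These two values lie within the usual scatter of repeated measurements, so compound 1 cannot be separated from compound 2 on these numbers.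

Compound 3 (`CC1=NN(C(=O)CSCc2nc3cc([N+](=O)[O-])ccc3[nH]2)C(=O)C1`) has not yet been measured. It keeps the rest of compound 1 and changes one group: a group of 7 heavy atoms (4 carbon, 2 nitrogen, 1 oxygen; one five-membered non-aromatic ring with 2 hetero atoms) in place of a group of 6 heavy atoms (6 carbon; one six-membered aromatic ring of carbon only), on a carbonyl carbon. In words, a group with one five-membered non-aromatic ring with 2 hetero atoms takes the place of phenyl, on a carbonyl carbon.

Within the data shown here, no measured pair shows what this particular swap does. Compound 2 carries a very different group on its carbonyl carbon and gives 11300 nM, so a large change is not expected here. The expected step is a 1.3-fold lower number from compound 1 to compound 3 (0.12 log units; within the scatter), which is no step beyond the scatter, though two measured compounds offer only thin support. For compound 3, the estimated value is 14000 nM, with an expected range of 5000 nM to 40000 nM.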

Compound 3, half-maximal inhibitory concentration: 8070 nM
For compound 3 the middle estimate is 1.7-fold (0.24 log units) above the measured one, within the range that was stated.
By their numbers in this assay, from the lowest: compounds 3, 2 and 1 (each within the scatter of the next, the first and the last beyond it).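

In this assay, the group on the carbonyl carbon now shows a readable effect: putting the five-membered non-aromatic ring with 2 hetero atoms in place of phenyl gives a 2.3-fold lower number from compound 1 to compound 3 (0.36 log units; beyond the scatter). The step is modest, but the two earlier compounds could not show even this much, as their values lay within the scatter of each other. It also shows that phenyl is not needed at this place to keep this level of inhibition, although the entering group has 2 hydrogen-bond acceptors and phenyl has 0, and a single pair cannot tie the step to that count or to any other feature; nothing measured here accounts for the change.

Still open, going by these compounds, is whether a simple amine such as dimethylamino, a pyridine ring or a short open chain such as ethyl on the same carbonyl carbon would move the number further, or back towards that of compound 1. Also open, on these data alone, is whether the step seen on these cells would hold on other cell lines.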